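The source may hold more compounds than are shown below. What is called first, only, known or untested is meant among the compounds shown, and "the series" means these compounds.

Compound 1, with structure `C=CCONC(=O)Cn1ccc(C(=O)N[C@@H](C)C(=O)N[C@H](C(=O)O)C(C)C)c1`, gives > 128000 nM in a functional assay on MRC5 cells (Homo sapiens) for inhibition, read by microscopy and resazurin assay, with a stated time of 72 h (a higher number here means a weaker inhibitor, a lower number a stronger inhibitor), which is a limit of the assay and not a number.
Compound 2, with structure `CC(C)[C@H](NC(=O)CNC(=O)c1ccn(CC(=O)NOCc2ccccc2)c1)C(=O)O`, gives > 128000 nM in this assay, again a limit of the assay.
Compound 3, with structure `CC(C)C[C@H](NC(=O)CNC(=O)c1ccn(CC(=O)NOCc2ccccc2)c1)C(=O)O`, gives > 128000 nM in this assay, once more a limit of the assay.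

Compound 2 therefore stands at the limit of this assay, and it shares that position with every other measured compound, since (the limit of > 128000 nM in this assay, at which 3 of the 3 values shown sit). Going by the values given here, the one measured step between neighbours, a step that the two limits leave unreadable from compound 2 to compound 3, cannot be read because both of its ends are limits. Compound 4, with structure `CC(C)[C@H](NC(=O)[C@H](C)NC(=O)c1ccn(CC(=O)NOCc2ccccc2)c1)C(=O)O`, differs from compound 2 by methyl in place of hydrogen on a saturated chain carbon bound to an amide-type nitrogen and a carbonyl carbon. Among the compounds with values here, compound 1 already carries a methyl at that same place and also sits at the limit, so no measured step speaks for any readable change in this assay from this substitution. The step from compound 2 to compound 4 is expected to be a step that the limit leaves unreadable from compound 2 to compound 4, that is, nothing beyond the scatter. Compound 4 is accordingly estimated at 200000 nM in this assay, with a range from 60000 nM to 600000 nM, and most likely the assay again reports only a limit.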

Compound 4, half-maximal inhibitory concentration: > 128000 nM
Compound 4 gave a limit, no number; the forecaster's own chance of this, stated with the estimate: 85%; the middle value is on the limit's open side.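

In this assay compound 4 gives > 128000 nM, a limit of the assay and not a number, so the steps to it from compound 2 and compound 1 cannot be read. The compounds shown leave open which change to the shared core, if any, would give a measurable value in this assay.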